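A few compounds are considered here, and "the series" means these few. Any claim that something is new, unique, unknown or untested is made for them only; others in the source may bear on it.

Working notes on the carbamate series.

Compound 3, `CC(OC(=O)C(C)C)OC(=O)N1CCN(C(=O)c2nc(Nc3cc(C4CC4)[nH]n3)c3cc(Cl)ccc3n2)C[C@H]1C`, stands second highest of the three numbers in an assay for inhibition of serine/threonine-protein kinase PAK 4 (Homo sapiens), read by FRET and Z'-LYTE, with a stated time of 60 min, tested at 0.5 uM, in the presence of a further agent that is not named here; on this read-out higher numbers stand for a stronger effect at the one concentration tested and lower numbers for a weaker effect: compound 3 gives 9.4%. Compound 1, `CCOC(=O)N1CCN(C(=O)c2nc(Nc3cc(C4CC4)[nH]n3)c3cc(Cl)ccc3n2)C[C@H]1C`, gives 42.4%, and compound 2, `CCCCCOC(=O)N1CCN(C(=O)c2nc(Nc3cc(C4CC4)[nH]n3)c3cc(Cl)ccc3n2)C[C@H]1C`, gives -3.8%. Going by the values given here, the one compound still to be measured is compound 4, `C[C@@H]1CN(C(=O)c2nc(Nc3cc(C4CC4)[nH]n3)c3cc(Cl)ccc3n2)CCN1C(=O)OCc1ccccc1`. It differs from compound 3 by benzyl in place of 1-((isopropylcarbonyl)oxy)ethyl on an oxygen next to a carbonyl group.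

All three measured steps bear on this change, since each alters what sits on the oxygen next to the carbonyl group. Lengthening the chain there cost a number 46.2 percentage points lower from compound 1 to compound 2 (beyond the scatter), and attaching the (isopropylcarbonyl)oxy group cost a number 33 percentage points lower from compound 1 to compound 3 (beyond the scatter); between the two larger groups, a number 13.2 percentage points higher from compound 2 to compound 3 (beyond the scatter). So every enlargement from the small group of compound 1 has lowered inhibition beyond the scatter, while exchanging one bulky group for another moved the number only modestly. Benzyl is another bulky group in the same place, so the step from compound 3 to compound 4 is expected to be small, likely downward or none beyond the scatter, a number 3.4 percentage points lower from compound 3 to compound 4 (within the scatter). Compound 4 is therefore estimated at 6%, within -15% to 30%.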

Compound 4, a percentage reported as inhibition, at one concentration (the size of the read-out at that concentration, not a potency): 4.4%
Compound 4: the middle estimate sits 1.6 percentage points above what was measured; the measured number falls inside the stated range.
By their numbers in this assay, from the lowest: compounds 2, 4 and 3 (each within the scatter of the next, the first and the last beyond it); then compound 1.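

In this assay, benzyl in place of 1-((isopropylcarbonyl)oxy)ethyl on an oxygen next to a carbonyl group gives a number 5 percentage points lower from compound 3 to compound 4 (within the scatter), so a six-membered aromatic ring of carbon only, with no hydrogen-bond acceptors, is not separated here from an open chain that carries two of them. Phenyl in place of butyl gives a number 8.2 percentage points higher from compound 2 to compound 4 (within the scatter), which places compound 4 within the scatter of both compound 2 and compound 3, even though those two lie beyond the scatter of each other, while phenyl in place of methyl gives a number 38 percentage points lower from compound 1 to compound 4 (beyond the scatter), so the aromatic ring does not restore the number of compound 1. The compounds at hand offer no measurement that accounts for these numbers.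

Open, as far as these compounds go, is how the number changes along the chain between the ethyl of compound 1 and the pentyl of compound 2, for instance with propyl or butyl, and whether methyl on the same oxygen would stand with compound 1. Also open, from the compounds shown here alone, is whether a benzyl carrying an amine or a carboxylic acid would stay with compound 4, and how any of these numbers at one concentration would translate into potency.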